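Compound 3 to compound 4: trifluoromethoxy on the series

The source may report more compounds than this note shows. Statements on the series, on what has been measured and on what is new or still open speak of the compounds shown alone.

In a functional assay on HOP-62 cells (Homo sapiens) for inhibition, read by sulforhodamine B assay (a higher number here means a weaker inhibitor of growth, a lower number a stronger inhibitor of growth), compound 3 `Oc1cccc2[nH]c(-c3ccc(-c4ccc(-c5ccccc5)cc4)cc3)nc12` gives 9040 nM, the middle of the three measured numbers. Compound 1 `c1ccc(-c2ccc(-c3ccc(-c4nc5ccccc5[nH]4)cc3)cc2)cc1` gives 100000 nM, and compound 2 `COc1cc(-c2ccc(-c3ccc(-c4nc5cc(C)ccc5[nH]4)cc3)cc2)cc(OC)c1OC` gives 2370 nM.

Compound 4 `Oc1cccc2[nH]c(-c3ccc(-c4ccc(-c5ccc(OC(F)(F)F)cc5)cc4)cc3)nc12` is compound 3 with one change: trifluoromethoxy in place of hydrogen on an aromatic carbon. In words, trifluoromethoxy replaces hydrogen on an aromatic carbon, para to a large group.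

For the measured compounds named here, no measured step covers this change. Going by the values given here, the only step available, an 11-fold lower number from compound 1 to compound 3 (1.04 log units; beyond the scatter), is large, but it is a different change, hydroxy in place of hydrogen, and cannot be transferred in size. Compound 2, at 2370 nM, also carries groups on the ring that changes here, but it differs from compound 3 in more than one place, so its support is weak. A small move toward a lower number in this assay is therefore expected, not clearly beyond the scatter.

The expected step is a 1.8-fold lower number from compound 3 to compound 4 (0.26 log units; within the scatter).

The estimated value for compound 4 is 5000 nM, with an expected range of 1800 nM to 15000 nM.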

Compound 4, concentration for 50% growth inhibition: 2270 nM
Beside the measured number, compound 4's estimate is 2.2-fold (0.34 log units) above it, and the stated range covers the measured number.
By their numbers in this assay, from the lowest: compounds 4 and 2 (each within the scatter of the next); then compound 3; then compound 1.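

Adding trifluoromethoxy para to a large group gives a 4.0-fold lower number from compound 3 to compound 4 (0.60 log units; beyond the scatter) in this assay, so this position accepts a group of 5 heavy atoms and growth inhibition gains beyond the scatter. For the compounds shown here, until now the only single-place step was the hydroxy change, an 11-fold lower number from compound 1 to compound 3 (1.04 log units; beyond the scatter), which left the ring carrying the new group unexplored; the trifluoromethoxy step shows that this ring also affects the number, with the hydroxy group in place. Nothing measured here explains the step.

From the compounds shown here alone, whether trifluoromethoxy gives a similar step without the hydroxy group, on the core of compound 1, remains open. Also open, going by these compounds, is how an amine, a carboxylic acid or a longer alkyl chain at the same position would compare with trifluoromethoxy.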